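This account rests on a few compounds, and the source may have more. Where it says the series, first, only, none or still open, it means among the compounds named here.

Measured so far:
compound 1 `CC1=C(N2CC2)C(=O)C(CCCOC(N)=O)=C(N2CC2)C1=O`, 6.18
compound 2 `CCC(COC(N)=O)C1=C(N2CC2)C(=O)C(C)=C(N2CC2)C1=O`, 6.18

Both values come from a functional assay on L1210 cells (Mus musculus), with a stated time of 12 days; a lower number here means a less potent compound, a higher number a more potent compound, by a factor of ten per unit of this negative logarithm. Compound 1 stands level with compound 2 at the digits shown; the two lie within the usual scatter, so neither can be set above the other. Compound 3 `CC1=C(N2CC2)C(=O)C(N2CC2)=C(N2CC2)C1=O` has not yet been measured. It differs from compound 1 in one place: a group of 3 heavy atoms (2 carbon, 1 nitrogen; one three-membered non-aromatic ring with 1 hetero atom) in place of a group of 7 heavy atoms (4 carbon, 1 nitrogen, 2 oxygen; no ring), on a double-bonded ring carbon. For the measured compounds named here, no measured pair shows a step of this kind, so how far this change moves the value in this assay is unknown. A shift within the scatter is expected, with compound 3 estimated to give 6, somewhere between 5.3 and 6.7. The expected step is a number 0.18 log units lower from compound 1 to compound 3 (within the scatter).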

Compound 3, logarithm of the reciprocal of the active concentration, log(1/C): 6.77
Estimate against measurement, compound 3: 0.77 log units below; measured number outside the range, above it.
By their numbers in this assay, from the lowest: compounds 1 and 2 (each within the scatter of the next); then compound 3.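

Placing aziridin-1-yl on the double-bonded ring carbon, in place of the open chain of compound 1, gives a number 0.59 log units higher from compound 1 to compound 3 (beyond the scatter) in this assay on this shared core. This position therefore responds to what it carries, and the chain with its hydrogen-bond donor is not needed to reach this level. Nothing measured here explains why the number moves.

Going by these compounds, whether the rise comes from aziridin-1-yl itself or from the loss of the chain stays open. A methyl group or a simple open-chain amine at this place would help separate the two.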